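The source may report more compounds than this note shows. Statements on the series, on what has been measured and on what is new or still open speak of the compounds shown alone.

Measured compounds in a functional assay on SW-620 cells (Homo sapiens) for inhibition, read by MTT assay, with a stated time of 72 h; on this read-out lower numbers stand for stronger inhibition and higher numbers for weaker inhibition:
- compound 1 `COc1cc(NC(C)CCCNC(=O)NNC(=O)Nc2cccc(F)c2)c2ncccc2c1`: 9500 nM
- compound 2 `COc1cc(NC(C)CCCNC(=O)NNC(=O)Nc2ccc(Br)cc2)c2ncccc2c1`: 17000 nM
- compound 3 `COc1cc(NC(C)CCCNC(=O)Nc2ccc(C(F)(F)F)cc2)c2ncccc2c1`: 22000 nM

Compound 3 gives the highest of the three numbers. Its nearest neighbour is compound 2, with a 1.3-fold higher number from compound 2 to compound 3 (0.11 log units; within the scatter), a step that stays within the scatter. The furthest is compound 1, with a 2.3-fold higher number from compound 1 to compound 3 (0.36 log units; beyond the scatter), a modest step beyond the scatter. Compound 1 and compound 2 differ by a 1.8-fold higher number from compound 1 to compound 2 (0.25 log units; within the scatter), which is also within the scatter. Across the whole set the spread is narrow.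

Compound 4 `COc1cc(NC(C)CCCNC(=O)Nc2ccc(O)cc2)c2ncccc2c1` is the next member. Compared with compound 3 the change is hydroxy in place of trifluoromethyl on an aromatic carbon.

Among the measured compounds shown here, none of the measured steps makes this exchange: compound 1 to compound 2 swaps one halogenated aryl for another, and the steps into compound 3 change both the linker and the aryl substituent. What the three steps do show is that aryl-side changes in this series move the read-out only slightly. The trifluoromethyl-to-hydroxy swap is therefore expected to give at most a small step in this assay, with no firm direction, and compound 4 is estimated at 20000 nM (range 8000 nM to 50000 nM), i.e. an expected step of a 1.1-fold lower number from compound 3 to compound 4 (0.04 log units; within the scatter).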

Compound 4, half-maximal inhibitory concentration: 30000 nM
Estimate against measurement, compound 4: 1.5-fold (0.18 log units) below, and the stated range covers the measured number.
By their numbers in this assay, from the lowest: compounds 1, 2, 3 and 4 (each within the scatter of the next, the first and the last beyond it).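

In this assay, among the compounds shown here, this is the first direct reading of a single exchange on the aromatic carbon para to a large group: a 1.4-fold higher number from compound 3 to compound 4 (0.13 log units; within the scatter). The read-out therefore stays within the scatter even though four heavy atoms with no hydrogen-bond donor or acceptor give way to one heavy atom that counts as one donor and one acceptor, so this pair gives no sign that the position is sensitive to this change. The wider comparisons, which alter the group on the amide-type nitrogen, do not read alike: a 1.8-fold higher number from compound 2 to compound 4 (0.25 log units; within the scatter), whereas a 3.2-fold higher number from compound 1 to compound 4 (0.50 log units; beyond the scatter), and nothing shown accounts for either the flat step or the modest one.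

An amine or a carboxylic acid on the same aromatic carbon would show whether this position can produce a step beyond the scatter, or whether the flat reading extends to other groups there. Also open, as far as these compounds go, is whether hydroxy behaves the same way on the aryl group of the longer chain carried by compound 1 and compound 2, where a direct single-place comparison with compound 4 would separate the aryl change from the chain change.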